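The source may hold more compounds than are shown below. What is called first, only, known or untested is meant among the compounds shown, and "the series" means these compounds.

In an in vitro ADME assay on microsomes from liver (Mus musculus) for pharmacokinetics, read by LC-MS, with a stated time of 10 min, tested at 1 uM (on this read-out higher numbers stand for fast clearance and lower numbers for slow clearance), compound 1 (`COc1ccc(NC(=O)[C@H]2CN(C)C[C@@H]2c2ccc(/C=C/C(=O)Nc3ccccc3N)cc2)cc1`) gives 54 mL/min/kg, compound 2 (`CN1C[C@H](C(=O)Nc2ccc(F)c(Br)c2)[C@@H](c2ccc(/C=C/C(=O)Nc3ccccc3N)cc2)C1`) gives 43 mL/min/kg and compound 3 (`CN1C[C@H](C(=O)Nc2ccc(Cl)cc2F)[C@@H](c2ccc(/C=C/C(=O)Nc3ccccc3N)cc2)C1`) gives 43 mL/min/kg, so compound 3 sits level with compound 2 and within the scatter of compound 1. Compound 4 (`CN1C[C@H](C(=O)NC2CC2)[C@@H](c2ccc(/C=C/C(=O)Nc3ccccc3N)cc2)C1`) differs from compound 3 in one place: cyclopropyl in place of 4-chloro-2-fluorophenyl on an amide-type nitrogen. Three measured steps swap one phenyl group for another on that amide-type nitrogen: a 1.3-fold lower number from compound 1 to compound 2 (0.10 log units; within the scatter), a 1.3-fold lower number from compound 1 to compound 3 (0.10 log units; within the scatter) and no change at the digits printed from compound 2 to compound 3 (within the scatter), all within the scatter. None of them puts cyclopropyl there, so they guide only loosely. On this evidence, no step beyond the scatter is expected in this assay. The estimated step is a 1.1-fold lower number from compound 3 to compound 4 (0.03 log units; within the scatter). For compound 4 the expected clearance is 40 mL/min/kg, with an estimated range from 20 mL/min/kg to 70 mL/min/kg.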

Compound 4, clearance: 7 mL/min/kg
For compound 4 the middle estimate is 5.7-fold (0.76 log units) above the measured one; the whole stated range lies above it.
By their numbers in this assay, from the lowest: compound 4; then compounds 2, 3 and 1 (each within the scatter of the next).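

Among compounds 1, 2 and 3, swapping one phenyl group for another on this amide-type nitrogen left this assay within the scatter, so nothing yet showed that this position could shift clearance. Cyclopropyl shows that it can, with a 6.1-fold lower number from compound 3 to compound 4 (0.79 log units; beyond the scatter) and a 6.1-fold lower number from compound 2 to compound 4 (0.79 log units; beyond the scatter) and a 7.7-fold lower number from compound 1 to compound 4 (0.89 log units; beyond the scatter) all beyond the scatter. Nothing available explains why the number falls with this change.

On these data alone, it remains open whether losing the aromatic ring or simply having fewer heavy atoms matters. Cyclohexyl or a short chain such as ethyl on the same nitrogen would help separate the two.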